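Two methyl additions on a shared acid-type core

A few compounds are considered here, and "the series" means these few. Any claim that something is new, unique, unknown or untested is made for them only; others in the source may bear on it.

Compound 1, `CC(C)c1ccc(CC(C)(Oc2ccc(C(C)C)cc2)C(=O)O)cc1`: 5 mg/kg
Compound 2, `CC(C)c1ccc(OC(C)(Cc2ccc(C(C)(C)C)cc2)C(=O)O)cc1`: 5 mg/kg
Compound 3, `CCc1ccc(CC(C)(Oc2ccc(C(C)C)cc2)C(=O)NS(=O)(=O)C(F)(F)F)cc1`: a limit of > 10 mg/kg

The study looks at a functional assay on the whole organism for inhibition, with Rattus norvegicus as the target; a lower number here means that less compound is needed, a higher number that more compound is needed for the effect. In this assay compound 1 gives 5 mg/kg, and compound 2 gives 5 mg/kg. The two are joined by one change, (methyl in place of hydrogen on a saturated chain carbon bound to an aromatic carbon and two saturated chain carbons), and the step of no change at the digits printed from compound 1 to compound 2 (within the scatter) stays flat. For compound 3 the result is a limit rather than a number, > 10 mg/kg; this is described by the limit of > 10 mg/kg in this assay, at which 1 of the 3 values shown sits. How the core of compound 3 differs from the core of compound 1 is not broken down here.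

Compound 4, `CCCc1ccc(CC(C)(Oc2ccc(C(C)C)cc2)C(=O)NS(=O)(=O)C(F)(F)F)cc1`, has not yet been measured. It stands to compound 3 as methyl in place of hydrogen on a saturated chain carbon, two bonds along the chain from an aromatic carbon. For the measured compounds named here, this is the same kind of change as the one from compound 1 to compound 2, but not the same: there the methyl entered on a saturated chain carbon bound to an aromatic carbon and two saturated chain carbons, here on a saturated chain carbon, two bonds along the chain from an aromatic carbon.

The estimated step that the limit leaves unreadable from compound 3 to compound 4 for compound 4 rests on the flat step no change at the digits printed from compound 1 to compound 2 (within the scatter) seen for this kind of change. Compound 4 is thus expected to give about 12 mg/kg, most likely between 5 mg/kg and 30 mg/kg, and it is expected that this assay may again report only a limit for compound 4.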

Compound 4, dose for half-maximal effect: > 10 mg/kg
Compound 4: no number, only a limit (the forecaster's own chance of this, stated with the estimate: 65%); the middle value lies beyond the limit too.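

For the compounds shown here, compound 3 and compound 4 are both reported in this assay only as limits, so no step between them can be read. The limit for compound 4 is > 10 mg/kg, and the values shown now gather there: the limit of > 10 mg/kg in this assay, at which 2 of the 4 values shown sit. The compounds shown leave open what number lies behind either limit and whether the change from 4-ethylphenyl to 4-propylphenyl alters the dose needed at all.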